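The compounds below may be only part of what the source reports. "The series", "measured", "known", "first", "only" and "open" are said of these compounds alone.

Compound 3 `CN1CC(c2ccc(Cl)cc2)[C@@]2(NC(=S)N(c3ccc(F)c(Cl)c3)C2=O)[C@@]12C(=O)Nc1ccccc12` gives 9080 nM in a functional assay on HepG2 cells (Homo sapiens) for cytotoxicity, read by MTT assay, with a stated time of 48 h (on this read-out higher numbers stand for weaker inhibition and lower numbers for stronger inhibition), the lowest of the three numbers in hand. Compound 1 `CN1CC(c2ccc(Cl)cc2)[C@@]2(NC(=S)N(c3ccc(F)c(Cl)c3)C2=O)[C@@]12C(=O)Nc1ccc(Br)cc12` gives 11100 nM, and the step of a 1.2-fold lower number from compound 1 to compound 3 (0.09 log units; within the scatter) shows that hydrogen in place of bromo on an aromatic carbon leaves the number within the scatter, so no order between compound 1 and compound 3 can be read. Compound 2 `CC(C)Oc1ccc(C2CN(C)[C@]3(C(=O)Nc4ccc(Br)cc43)[C@]23NC(=S)N(c2ccc(F)c(Cl)c2)C3=O)cc1` gives 34600 nM, separated from compound 3 by a gap beyond the scatter.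

Compound 4 `CC(C)Oc1ccc(C2CN(C)[C@]3(C(=O)Nc4ccccc43)[C@]23NC(=S)N(c2ccc(F)c(Cl)c2)C3=O)cc1` differs from compound 3 by isopropoxy in place of chloro on an aromatic carbon. Among the compounds with values here, the same change has been measured once, a 3.1-fold higher number from compound 1 to compound 2 (0.49 log units; beyond the scatter), and that step is the one that bears on compound 4. Since the bromo-to-hydrogen change moved the number only within the scatter, the core of compound 3 is expected to respond to the exchange much as the core of compound 1 did. A modest rise in the number is therefore expected, a 3.1-fold higher number from compound 3 to compound 4 (0.49 log units; beyond the scatter). Compound 4 is estimated at 28000 nM in this assay, with a range of 14000 nM to 56000 nM.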

Compound 4, half-maximal inhibitory concentration: 49900 nM
Beside the measured number, compound 4's estimate is 1.8-fold (0.25 log units) below it; the range from low to high includes it.
By their numbers in this assay, from the lowest: compounds 3 and 1 (each within the scatter of the next); then compounds 2 and 4 (each within the scatter of the next).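

In this assay, 4-chlorophenyl to 4-isopropoxyphenyl also raises the number on the core without bromo, a 5.5-fold higher number from compound 3 to compound 4 (0.74 log units; beyond the scatter), so the direction of this change holds on both cores shown, and the size of the step does not separate them: the same change on two cores in this assay, a 3.1-fold higher number (0.49 log units; beyond the scatter) from compound 1 to compound 2 and a 5.5-fold higher number (0.74 log units; beyond the scatter) from compound 3 to compound 4, 1.8-fold (0.25 log units) apart, within the scatter of two such steps. Hydrogen in place of bromo, now read with isopropoxy in place as well, stays within the scatter, a 1.4-fold higher number from compound 2 to compound 4 (0.16 log units; within the scatter), so no order can be read within that pair: the same change on two cores in this assay, a 1.2-fold lower number (0.09 log units; within the scatter) from compound 1 to compound 3 and a 1.4-fold higher number (0.16 log units; within the scatter) from compound 2 to compound 4, 1.8-fold (0.25 log units) apart, within the scatter of two such steps. Across these four compounds, the exchange of chloro for isopropoxy moves the number beyond the scatter, while the exchange of bromo for hydrogen does not.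

A single exchange cannot separate the part played by the oxygen from that of the branched carbon chain. As far as these compounds go, how a methoxy group, an amine or a carboxylic acid at this place would read remains open.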